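The source may report more compounds than this note shows. Statements on the series, on what has been measured and on what is new or still open speak of the compounds shown alone.

Measured so far in a functional assay on PC-3M cells (Homo sapiens) for cytotoxicity, read by MTT assay, with a stated time of 48 h; a higher number here means a weaker inhibitor, a lower number a stronger inhibitor:

Compound 1, `C=CCSc1nnc(CCC)n1N1C(=O)c2ccccc2C1=O`: in this assay compound 1 gives > 200000 nM, which is a limit of the assay and not a number.
Compound 2, `CCCc1nnc(SCc2ccccc2)n1N1C(=O)c2ccccc2C1=O`: in this assay compound 2 gives > 200000 nM, likewise a limit of the assay.

Compound 2 therefore stands only at a limit in this assay; no number places it. For the measured compounds named here, the one step available, a step that the two limits leave unreadable from compound 1 to compound 2, has no readable size, both of its ends being limits; this is the whole of the evidence, (the limit of > 200000 nM in this assay, at which 2 of the 2 values shown sit).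

The next compound is compound 3, `C#CCSc1nnc(CCC)n1N1C(=O)c2ccccc2C1=O`. The change from compound 2 is ethynyl in place of phenyl on a saturated chain carbon bound to a sulfur. Going by the values given here, the only step that bears on it is the unreadable one from compound 1 to compound 2, so no direction or size can be taken from it. With the shared core unchanged and both measured compounds sitting at the limit, compound 3 is expected to sit at a limit as well, and the step that the limit leaves unreadable from compound 2 to compound 3 is expected to be none beyond the scatter. The estimate for compound 3 in this assay is 250000 nM, in the range 100000 nM to 1000000 nM.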

Compound 3, half-maximal inhibitory concentration: > 200000 nM
Compound 3 was reported as a limit (the forecaster's own chance of this, stated with the estimate: 85%); the middle value does not contradict the limit.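

In this assay compound 3 gives > 200000 nM, a limit of the assay and not a number. For the compounds shown here, no step among compound 1, compound 2 and compound 3 can be read: the limit of > 200000 nM in this assay, at which 3 of the 3 values shown sit. The compounds shown leave open whether any group on the saturated chain carbon bound to a sulfur gives a measurable value in this assay.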